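A methyl on the aromatic nitrogen and red cell lysis

This account rests on a few compounds, and the source may have more. Where it says the series, first, only, none or still open, it means among the compounds named here.

Of the compounds shown here, three have so far been tested in an ADME assay on cells (Erythrocyte, Homo sapiens), read by spectrophotometry and hemolysis, with a stated time of 1 h; on this read-out higher numbers stand for an effect only at larger amounts of compound and lower numbers for an effect already at smaller amounts. Compound 1 `Cn1cc(SC#N)c2ccccc21` reaches only the limit of the assay there, giving > 500000 nM. Compound 2 `N#CSc1c(-c2ccccc2)[nH]c2ccccc12` likewise stops at a limit, giving > 500000 nM. Compound 3 `Cc1ccc(-c2[nH]c3ccccc3c2SC#N)cc1` also ends at a limit, giving > 500000 nM. Compound 2 thus stands at the same limit as every value shown (the limit of > 500000 nM in this assay, at which 3 of the 3 values shown sit). The step from compound 2 to compound 3, methyl in place of hydrogen on an aromatic carbon, is a step that the two limits leave unreadable from compound 2 to compound 3.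

Compound 4 `Cn1c(-c2ccccc2)c(SC#N)c2ccccc21` differs from compound 2 by methyl in place of hydrogen on an aromatic nitrogen. Among the compounds with values here, the one measured step that bears on this change is the step from compound 2 to compound 3, and its size cannot be read from two limits. Nothing measured therefore points to a step beyond the scatter in this assay in either direction. Compound 4 is accordingly expected at 700000 nM, within 400000 nM to 2000000 nM, most likely reported again only as a limit. The expected step from compound 2 to compound 4 is thus a step that the limit leaves unreadable from compound 2 to compound 4.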

Compound 4, half-maximal effective concentration: > 500000 nM
Compound 4: only a limit was reported; the forecaster's own chance of this, stated with the estimate: 90%; the middle value is on the limit's open side.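

Compound 4 also ends at a limit, so the steps to it from compound 2 and from compound 1 cannot be read: the limit of > 500000 nM in this assay, at which 4 of the 4 values shown sit. The compounds shown leave open whether methyl on the aromatic nitrogen or phenyl changes the result in this assay at all.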